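A few compounds are considered here, and "the series" means these few. Any claim that something is new, unique, unknown or untested is made for them only; others in the source may bear on it.

Measured so far in a physicochemical assay for solubility, in phosphate buffer, measured as thermodynamic solubility, at pH 7.4; on this read-out lower numbers stand for lower solubility and higher numbers for higher solubility:

- compound 1 `CCCCOc1ccc(-c2cccc(C(=O)O)c2)cc1CNC(=O)c1ccc(C(F)(F)F)cc1F`: < 1 ug/mL
- compound 2 `CCCCOc1ccc(-c2ccc(C(=O)O)cc2F)cc1CNC(=O)c1ccc(C(F)(F)F)cc1F`: < 1 ug/mL

Compound 2 stands at < 1 ug/mL, which is a limit of the assay and not a true number. Compound 1 is also reported only as a limit, so the picture so far is simple: the limit of < 1 ug/mL in this assay, at which 2 of the 2 values shown sit.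

Compound 3 `CCCCOc1ccc(-c2c(F)ccc(C(=O)O)c2F)cc1CNC(=O)c1ccc(C(F)(F)F)cc1F` keeps the shared core and changes one group, para to a butoxy group: 3-carboxy-2,6-difluorophenyl replaces 4-carboxy-2-fluorophenyl (3-carboxy-2,6-difluorophenyl in place of 4-carboxy-2-fluorophenyl on an aromatic carbon).

Among the compounds with values here, the one measured step that bears on this change also swaps the carboxy-bearing group, and it is a step that the two limits leave unreadable from compound 1 to compound 2. That step has no readable size, so it offers no measured size or direction to carry forward. With so little to go on, no shift beyond the usual scatter is expected in this assay, in either direction. The expected step that the limit leaves unreadable from compound 2 to compound 3 is an estimate only. For compound 3 the estimated value is 0.7 ug/mL, with an expected range from 0.2 ug/mL to 3 ug/mL. A report of only a limit again is the more likely expected outcome.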

Compound 3, solubility: 21.7 ug/mL
Beside the measured number, compound 3's estimate is 31-fold (1.49 log units) below it, and the stated range ends below it.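

In this assay, putting 3-carboxy-2,6-difluorophenyl at this place, para to a butoxy group, in place of 4-carboxy-2-fluorophenyl gives an at least 21-fold higher number from compound 2 to compound 3 (1.33 log units; beyond the scatter), and putting it in place of 3-carboxyphenyl gives an at least 21-fold higher number from compound 1 to compound 3 (1.33 log units; beyond the scatter). Within the data shown here, these are the first readable steps at this position, and they show that a change of this one group on the shared core can move the read-out well beyond the scatter, with the printed sizes standing as minimums. The earlier step between compound 1 and compound 2 cannot be read, as each of those two compounds is reported only as a limit of the assay and not as a true number: the limit of < 1 ug/mL in this assay, at which 2 of the 3 values shown sit.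

The compounds shown leave open whether the higher number goes with the second fluorine or with the particular arrangement of the carboxy and fluoro groups in 3-carboxy-2,6-difluorophenyl, since the entering group differs from both earlier groups in more than one feature. They also leave open how this assay would respond to an amine in place of the carboxylic acid, or to a longer chain in place of the butoxy group.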